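Extending the methyl to butyl on the benzyl group

The source may hold more compounds than are shown below. What is called first, only, known or untested is meant among the compounds shown, and "the series" means these compounds.

Compound 1 `CC(C)=CCn1ccc2cc(/C(C)=C/C(=O)Nc3ccccc3OCCCC(=O)O)ccc21` gives 120 nM in an assay on Prostate gland for inhibition of steroid 5-alpha-reductase (Rattus norvegicus); a higher number here means a weaker inhibitor, a lower number a stronger inhibitor. Compound 2 `C/C(=C\C(=O)Nc1ccccc1OCCCC(=O)O)c1ccc2c(ccn2Cc2cccc(C)c2)c1` gives 250 nM. Compound 3 `C/C(=C\C(=O)Nc1ccccc1OCCCC(=O)O)c1ccc2c(ccn2Cc2ccc(C)cc2)c1` gives 88 nM.

Compound 3 has the lowest number of the three, but its gap to compound 1 lies within the scatter; only compound 2 sits clearly higher, as a 2.8-fold lower number from compound 2 to compound 3 (0.45 log units; beyond the scatter) shows. Compound 4 `CCCCc1ccc(Cn2ccc3cc(/C(C)=C/C(=O)Nc4ccccc4OCCCC(=O)O)ccc32)cc1` differs from compound 3 by propyl in place of hydrogen on a saturated chain carbon bound to an aromatic carbon. For the measured compounds named here, no measured step lengthens a chain at this spot; the nearest comparisons, a 1.4-fold lower number from compound 1 to compound 3 (0.13 log units; within the scatter) and a 2.8-fold lower number from compound 2 to compound 3 (0.45 log units; beyond the scatter), exchange the whole group on the chain carbon bound to the aromatic nitrogen and stay modest. A step beyond the scatter in this assay is therefore not expected in either direction, so compound 4 is estimated at 80 nM (range 35 nM to 200 nM), an expected step of a 1.1-fold lower number from compound 3 to compound 4 (0.04 log units; within the scatter).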

Compound 4, half-maximal inhibitory concentration: 100 nM
Compound 4: middle estimate off by 1.3-fold (0.10 log units), on the low side; measured number inside the range.
By their numbers in this assay, from the lowest: compounds 3, 4 and 1 (each within the scatter of the next); then compound 2.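

In this assay, the 4-methylbenzyl group can carry a butyl chain in place of its methyl without a step beyond the scatter (a 1.1-fold higher number from compound 3 to compound 4 (0.06 log units; within the scatter)), so this position accepts a longer group. Compound 4 keeps the clear gap to the 3-methylphenyl compound (a 2.5-fold lower number from compound 2 to compound 4 (0.40 log units; beyond the scatter)) and stays level with the 2-methylprop-1-en-1-yl compound (a 1.2-fold lower number from compound 1 to compound 4 (0.08 log units; within the scatter)). Nothing available gives a reason for this result. From the compounds shown here alone, whether a hexyl chain, or an amine or carboxylic acid at the end of the butyl chain, would fit equally well remains open.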